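This account rests on a few compounds, and the source may have more. Where it says the series, first, only, none or still open, it means among the compounds named here.

Compound 1 `CCc1nn(CCCN2CCN(c3ccc(C)cc3)CC2)c(=O)c(N)c1C(C)=O`: 42%
Compound 2 `CCC(=O)c1c(C)nn(CCCN2CCN(c3ccc(C)cc3)CC2)c(=O)c1N`: 40%

In a functional assay on the whole organism (Abdomen, strain Swiss) for inhibition, with Mus musculus as the target, with stated times of 30 min, 10 min and 5 min, at a dose of 20 mg/kg by the oral route (a lower number here means a weaker effect, a higher number a stronger effect of the compound at the dose given), compound 2 gives 40%, the lowest of the two numbers shown, yet the nearest value, that of compound 1 at 42%, lies within the scatter, so the two compounds cannot be told apart. Compound 3 `CCCC(=O)c1c(C)nn(CCCN2CCN(c3ccc(C)cc3)CC2)c(=O)c1N` differs from compound 2 by methyl in place of hydrogen on a saturated chain carbon, two bonds along the chain from a carbonyl carbon. Among the measured compounds shown here, no measured step is available for this difference, so the expected step from compound 2 to compound 3, no change at the digits printed from compound 2 to compound 3 (within the scatter), is set at none beyond the scatter. Compound 3 is therefore estimated at 40% in this assay, within 25% to 55%.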

Compound 3, a percentage reported as inhibition, in the whole organism at one dose (the size of the read-out at that dose, not a potency): 25%
Compound 3: the middle estimate sits 15 percentage points above what was measured, and the stated range covers the measured number.
By their numbers in this assay, from the lowest: compound 3; then compounds 2 and 1 (each within the scatter of the next).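

In this assay, the change from propanoyl to propylcarbonyl, methyl in place of hydrogen on a saturated chain carbon, two bonds along the chain from a carbonyl carbon, gives a number 15 percentage points lower from compound 2 to compound 3 (beyond the scatter). Among the compounds shown here, this is the first readable step at this position, and it shows that the read-out at the dose given responds to this single added carbon. Nothing measured here accounts for the step. Going by these compounds, whether a longer chain such as pentanoyl, or an amine on this chain, would lower the number further stays open. A single step sets no trend.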